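The source may report more compounds than this note shows. Statements on the series, on what has been measured and on what is new or still open speak of the compounds shown alone.

Compounds measured so far in a functional assay on the whole organism (Tail, strain ICR) with Mus musculus as the target, in the tail flick test, with a stated time of 30 min, at a dose of 25 umol/kg by the oral route; a higher number here means a stronger effect of the compound at the dose given, a lower number a weaker effect:
compound 1, `O=C(O)[C@@H]1CCCN1C(=O)CN(c1nc(Cl)nc2[nH]cnc12)C1CC1`: 31.5%
compound 2, `CSCC[C@H](NC(=O)CN(c1nc(Cl)nc2[nH]cnc12)C1CC1)C(=O)O`: 20.4%
compound 3, `O=C(CN(c1nc(Cl)nc2[nH]cnc12)C1CC1)N[C@@H](CO)C(=O)O`: 38.7%

Compound 3 holds the highest of the three numbers in this assay. One of its two gaps is a number 7.2 percentage points higher from compound 1 to compound 3 (within the scatter), within the scatter, so those two cannot be told apart, while the other gap is a number 18.3 percentage points higher from compound 2 to compound 3 (beyond the scatter), a clear difference.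

Compound 4, `CC(C)[C@H](NC(=O)CN(c1nc(Cl)nc2[nH]cnc12)C1CC1)C(=O)O`, is not yet measured. It differs from compound 3 as follows: isopropyl in place of hydroxymethyl on a saturated chain carbon bound to an amide-type nitrogen and a carbonyl carbon. Within the data shown here, the step that bears most directly on this change is the one from compound 2 to compound 3, which also exchanged the side chain on the same saturated chain carbon and moved the number by a number 18.3 percentage points higher from compound 2 to compound 3 (beyond the scatter). Compound 4 goes the other way, from hydroxymethyl back to a side chain of carbon only, so a drop of modest size, beyond the scatter, is expected in this assay. The step from compound 1 to compound 3 changed a different part of the amide and says little here.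

Compound 4 is therefore expected to give about 25% in this assay, in the range 12% to 38%, a step of a number 13.7 percentage points lower from compound 3 to compound 4 (beyond the scatter) expected from compound 3.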

Compound 4, a percentage reported as activity, at one dose (the size of the read-out at that dose, not a potency): 31.2%
Compound 4: the middle estimate sits 6.2 percentage points below what was measured; low and high end bracket the measured number.
By their numbers in this assay, from the lowest: compound 2; then compounds 4, 1 and 3 (each within the scatter of the next).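

In this assay, the change to isopropyl on the saturated chain carbon bound to an amide-type nitrogen and a carbonyl carbon gives a number 7.5 percentage points lower from compound 3 to compound 4 (within the scatter) and so shows that hydroxymethyl at this place cannot be told apart from a side chain of carbon only. Isopropyl still separates from 2-(methylsulfanyl)ethyl, with a number 10.8 percentage points higher from compound 2 to compound 4 (beyond the scatter) as the step, so a side chain without a hydroxy group does not by itself bring the number down to that of compound 2. The step to the 2-carboxypyrrolidin-1-yl amide, read as a number 0.3 percentage points lower from compound 1 to compound 4 (within the scatter) in the listed direction, likewise shows no separation.

Nothing measured here accounts for these differences. Still open, going by these compounds, is how a longer carbon chain, a side chain ending in an amine or one ending in a carboxylic acid would behave at this place.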